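The source may report more compounds than this note shows. Statements on the series, on what has been measured and on what is new or still open speak of the compounds shown alone.

Compound 1, `O=C(CCSc1nnc(-c2ccncc2)s1)Nc1ccccc1`, was examined in an ADME assay on HepG2 cells (Homo sapiens) for cytotoxicity, with a stated time of 3 days; on this read-out higher numbers stand for lower toxicity in this test and lower numbers for higher toxicity in this test. In this assay compound 1 gives > 50000 nM, which is a limit of the assay and not a number. Compound 2, `CC(CSc1nnc(-c2ccncc2)s1)C(=O)Nc1ccccc1`, carries a methyl in place of hydrogen on a saturated chain carbon bound to a carbonyl carbon and a saturated chain carbon. In this assay compound 2 likewise gives > 50000 nM, again a limit rather than a number. The step that the two limits leave unreadable from compound 1 to compound 2 is thus not readable, since both values sit at the limit of > 50000 nM in this assay, at which 2 of the 2 values shown sit. Compound 3, `O=C(CCSc1nnc(-c2ccncc2)s1)Nc1c(Cl)cccc1Cl`, differs from compound 1 at another place: 2,6-dichlorophenyl in place of phenyl on an amide-type nitrogen. Among the compounds with values here, no measured step touches the amide-type nitrogen, so none bears directly on this change, and the single comparison available, between compound 1 and compound 2, is hidden by the two limits. The account therefore expects for compound 3 a step of a number no higher from compound 1 to compound 3 (the limit leaves the size open) of no readable size, with the value most probably sitting again at the limit. Compound 3 is estimated at 50000 nM, within a range from 20000 nM to 100000 nM.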

Compound 3, half-maximal cytotoxic concentration: 12600 nM
Beside the measured number, compound 3's estimate is 4.0-fold (0.60 log units) above it, and the stated range ends above it.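

In this assay compound 1 gives > 50000 nM, a limit of the assay and not a number. Within the data shown here, compound 3 is the first compound here with a measured number, so the amide-type nitrogen is a place where a change shows on this read-out: 2,6-dichlorophenyl in place of phenyl gives an at least 3.9-fold lower number from compound 1 to compound 3 (0.59 log units; beyond the scatter), which means higher toxicity in this test, with the true size of the step left open at the compound 1 end. The methyl step on the saturated chain still cannot be read, and the two compounds without a number remain at the same limit: the limit of > 50000 nM in this assay, at which 2 of the 3 values shown sit.

The compounds shown leave open whether a phenyl carrying a single chlorine, or one carrying a methoxy group or an amine instead, would also give a number in this test, so the step cannot yet be tied to the chlorines as such. They also leave open whether 2,6-dichlorophenyl gives a step of this kind on the methyl-bearing chain of compound 2 or on a longer chain.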